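Methyl-for-hydrogen steps at two places in one series

A few compounds are considered here, and "the series" means these few. Any claim that something is new, unique, unknown or untested is made for them only; others in the source may bear on it.

Measured compounds, with their values in a functional assay for agonist activity at G protein-coupled receptor 88 (Homo sapiens), read by HTRF and cAMP accumulation; a higher number here means that more compound is needed for the effect, a lower number that less compound is needed:
compound 1, `CC(C)[C@H](N)CN(C(=O)[C@@H]1C[C@H]1c1ccccc1)c1ccc(-c2ccccc2)cc1`, gives 1.1 nM
compound 2, `CC(C)(C)[C@H](N)CN(C(=O)[C@@H]1C[C@H]1c1ccccc1)c1ccc(-c2ccccc2)cc1`, gives 11 nM
compound 3, `CCc1ccc(-c2ccc(N(C[C@@H](N)[C@@H](C)CC)C(=O)[C@@H]3C[C@H]3c3ccccc3)cc2)cc1`, gives 44 nM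

Compound 1 and compound 2 differ in one place, (methyl in place of hydrogen on a saturated chain carbon bound to three saturated chain carbons). That step reads a 10-fold higher number from compound 1 to compound 2 (1.00 log units; beyond the scatter).

Compound 3 carries a different core from compound 1; the difference between the two cores is not broken down here. Compound 3 stands highest of the three numbers: against compound 2 it is a step beyond the scatter, and against compound 1 a larger one, also beyond the scatter.

Compound 4, `CCCc1ccc(-c2ccc(N(C[C@@H](N)[C@@H](C)CC)C(=O)[C@@H]3C[C@H]3c3ccccc3)cc2)cc1`, is not yet measured. It differs from compound 3 by methyl in place of hydrogen on a saturated chain carbon, two bonds along the chain from an aromatic carbon. This is the same kind of change as that from compound 1 to compound 2, a methyl entering for a hydrogen, but not the same change: in the earlier pair the place is a saturated chain carbon bound to three saturated chain carbons, whereas here the place is a saturated chain carbon two bonds along the chain from an aromatic carbon, so the ethyl on the distal ring becomes a propyl.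

For the measured compounds named here, the only measured methyl-for-hydrogen step, a 10-fold higher number from compound 1 to compound 2 (1.00 log units; beyond the scatter), sits at a different place, so it gives a direction but not a firm size for the present pair. For compound 4 the step is expected to be a 1.6-fold higher number from compound 3 to compound 4 (0.20 log units; within the scatter), smaller than the earlier one. Compound 4 is therefore expected at about 70 nM, with a likely range from 20 nM to 250 nM.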

Compound 4, half-maximal effective concentration: 61 nM
Compound 4: the middle estimate sits 1.1-fold (0.06 log units) above what was measured, and the stated range covers the measured number.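

In this assay the new step reads a 1.4-fold higher number from compound 3 to compound 4 (0.14 log units; within the scatter), so this methyl in place of hydrogen, 4-ethylphenyl to 4-propylphenyl, does not separate the two compounds. Set beside the earlier step, a methyl entering for a hydrogen does not keep one size from one core to another in this series: the same change on two cores in this assay, a 10-fold higher number (1.00 log units; beyond the scatter) from compound 1 to compound 2 and a 1.4-fold higher number (0.14 log units; within the scatter) from compound 3 to compound 4, 7.2-fold (0.86 log units) apart, beyond the scatter of two such steps

This does not show that the core alone sets the size of the step, since the two steps also sit at different places, one on a saturated chain carbon bound to three saturated chain carbons and the other on a saturated chain carbon two bonds along the chain from an aromatic carbon; two pairs also fix no general rule for the series.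

Still open, as far as these compounds go, is the size of each step with the same place on the other core, which would separate the effect of the place from that of the core. Also open, from the compounds shown here alone, is how a longer chain such as butyl, or an amine or a carboxylic acid in place of the propyl, would read in this assay.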